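Thiophene attachment on the carbonyl carbon

The source may hold more compounds than are shown below. What is called first, only, known or untested is meant among the compounds shown, and "the series" means these compounds.

Of the compounds shown here, two are measured so far. Compound 1 `COc1ccc(-c2cc3ccccc3nc2/C=C/C(=O)c2c(OC)cccc2OC)cc1` carries 2,6-dimethoxyphenyl on the carbonyl carbon and in a functional assay on H184B5F5/M10 cells (Homo sapiens) for antiproliferative activity, read by XTT assay, with a stated time of 72 h (a lower number here means a stronger inhibitor, a higher number a weaker inhibitor), gives 4470 nM. Compound 2 `COc1ccc(-c2cc3ccccc3nc2/C=C/C(=O)c2cccs2)cc1` carries thiophen-2-yl at the same place and in this assay gives 7030 nM. The single measured step, a 1.6-fold higher number from compound 1 to compound 2 (0.20 log units; within the scatter), does not tell the two apart, so compound 2 stands at the same level as compound 1 on the numbers shown. Compound 3 `COc1ccc(-c2cc3ccccc3nc2/C=C/C(=O)c2ccsc2)cc1` differs from compound 2 by thiophen-3-yl in place of thiophen-2-yl on a carbonyl carbon. Among the compounds with values here, no measured step compares the two thiophene attachments; the only step that touches this carbon swaps a whole aryl group and stays within the scatter, which is the sole guide. The step expected in this assay is a 1.0-fold lower number from compound 2 to compound 3 (0.00 log units; within the scatter), with no direction beyond the scatter. Compound 3 is therefore estimated at 7000 nM, in a range from 3000 nM to 16000 nM.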

Compound 3, half-maximal inhibitory concentration: 6390 nM
Compound 3: the middle estimate sits 1.1-fold (0.04 log units) above what was measured, and the stated range covers the measured number.
By their numbers in this assay, from the lowest: compounds 1, 3 and 2 (each within the scatter of the next).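

Working notes on the carbonyl carbon: in this assay, thiophen-3-yl in place of thiophen-2-yl gives a 1.1-fold lower number from compound 2 to compound 3 (0.04 log units; within the scatter), the first direct comparison of the two thiophene attachments, and it does not tell them apart. Thiophen-3-yl in place of 2,6-dimethoxyphenyl gives a 1.4-fold higher number from compound 1 to compound 3 (0.16 log units; within the scatter), so this attachment also stays level with the dimethoxyphenyl group, and all three aryl groups at this place now lie within the scatter of one another. Nothing available accounts for this flat reading.

Still open, going by these compounds, is whether a group of another kind on the carbonyl carbon, such as an amine like piperidin-4-yl or a phenyl ring bearing a carboxylic acid, would move the number beyond the scatter. Also open, on these data alone, is whether the two thiophene attachments stay level on a core carrying something other than the methoxy group.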